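A few compounds are considered here, and "the series" means these few. Any claim that something is new, unique, unknown or untested is made for them only; others in the source may bear on it.

Measured so far:
compound 1, `COc1cc(N)c(Cl)cc1C(=O)NC1CCN(CC2CCN(C(=O)C(C)N)CC2)CC1`: 5.06 nM
compound 2, `COc1cc(N)c(Cl)cc1C(=O)NC1CCN(CC2CCN(CCCNS(C)(=O)=O)CC2)CC1`: 21.1 nM
compound 3, `COc1cc(N)c(Cl)cc1C(=O)NC1CCN(CC2CCN(C(=O)CCN)CC2)CC1`: 9.5 nM

All three were tested in an assay on striatum for inhibition of 5-hydroxytryptamine receptor 4 (Cavia porcellus), read by radioligand binding; a lower number here means a stronger inhibitor, a higher number a weaker inhibitor. Compound 1 has the lowest number, with compound 3 within the scatter of it (a 1.9-fold higher number from compound 1 to compound 3 (0.27 log units; within the scatter)) and compound 2 clearly further off (a 4.2-fold higher number from compound 1 to compound 2 (0.62 log units; beyond the scatter)). Compound 4, `COc1cc(N)c(Cl)cc1C(=O)NC1CCN(CC2CCN(CCCCN)CC2)CC1`, is not yet measured. It differs from compound 1 in one place: 4-aminobutyl in place of (1-aminoethyl)carbonyl on an amine nitrogen in a ring. The step from compound 1 to compound 2 is the closest guide, since there too a chain replaced the (1-aminoethyl)carbonyl group on the same ring nitrogen, and the number rose modestly. Compound 4 keeps a primary amine like compound 1, so a smaller rise is expected, a 2.4-fold higher number from compound 1 to compound 4 (0.38 log units; beyond the scatter). Compound 4 is therefore estimated at 12 nM, within 4 nM to 35 nM.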

Compound 4, half-maximal inhibitory concentration: 6.47 nM
Compound 4: the middle estimate sits 1.9-fold (0.27 log units) above what was measured, within the range that was stated.
By their numbers in this assay, from the lowest: compounds 1, 4 and 3 (each within the scatter of the next); then compound 2.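

On this ring nitrogen, a carbonyl is not needed for a low number: 4-aminobutyl, which has none, stays within the scatter of both carbonyl-bearing groups (a 1.3-fold higher number from compound 1 to compound 4 (0.11 log units; within the scatter); a 1.5-fold lower number from compound 3 to compound 4 (0.17 log units; within the scatter)). Compound 2 has no carbonyl on this ring nitrogen either. Aminomethyl in place of methanesulfonamido at the chain end gives a difference beyond the scatter (a 3.3-fold lower number from compound 2 to compound 4 (0.51 log units; beyond the scatter)). No supporting data explain these results. On these data alone, whether a longer chain ending in an amine, or a chain ending in a carboxylic acid, would keep the number this low remains open.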